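The source may report more compounds than this note shows. Statements on the series, on what has been measured and on what is new or still open speak of the compounds shown alone.

Of the compounds shown here, two have so far been read in a physicochemical assay for solubility; on this read-out higher numbers stand for higher solubility and lower numbers for lower solubility. Compound 1 `NS(=O)(=O)c1ccc(NC(=O)c2cc(Cl)ccc2O)cc1` gives > 48 ug/mL, and this is a limit of the assay, not a number. Compound 2 `O=C(Nc1ccc(Cl)cc1Cl)c1cc(Cl)ccc1O` gives < 1 ug/mL, and this too is a limit of the assay, not a number. Compound 2 therefore offers no exact starting value for the step that follows. Compound 3 `O=C(Nc1ccc(Cl)cc1)c1cc(Cl)ccc1O` has not yet been measured. It differs from compound 2 by a single change, (hydrogen in place of chloro on an aromatic carbon), with hydrogen in place of chloro on an aromatic carbon, ortho to a large group and meta to a chloro group. For the measured compounds named here, no measured pair differs in this one place, so only a small rise in this assay is expected, one that may not clear the usual scatter. The expected change is an at least 2.0-fold higher number from compound 2 to compound 3 (0.30 log units; that floor lies within the scatter). The estimate for compound 3 is 2 ug/mL, in an expected range from 0.5 ug/mL to 8 ug/mL.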

Compound 3, solubility: < 1 ug/mL
Compound 3 ended at the assay's limit; the forecaster's own chance of this, stated with the estimate: 45%; middle value at least 2.0-fold (0.30 log units) away from the limit.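

Taking the chloro group off this position does not lift the compound clear of the floor of this assay: compound 3 gives < 1 ug/mL, which is a limit of the assay and not a number. Compound 2 and compound 3 both rest on limits, so the step between them cannot be read: the limit of < 1 ug/mL in this assay, at which 2 of the 3 values shown sit. What compound 3 adds is a readable comparison at another place in the molecule, where chloro in place of sulfamoyl gives an at least 48-fold lower number from compound 1 to compound 3 (1.68 log units; beyond the scatter).

On these data alone, how far compound 2 and compound 3 each lie under the limit stays unknown, so any small difference between them remains hidden. Also open, as far as these compounds go, is whether another group in place of sulfamoyl, such as an amine or a carboxylic acid, would give a value that falls between the two limits.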